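Chloro in place of hydrogen on two aromatic rings

The source may report more compounds than this note shows. Statements on the series, on what has been measured and on what is new or still open speak of the compounds shown alone.

Compound 1 `Cn1c(CN2CCC(c3ccccc3)CC2)nc2ccccc21` gives 200 nM in an assay on CHO cells with metabotropic glutamate receptor 2 (Homo sapiens) as the target, read by FLIPR; on this read-out higher numbers stand for an effect only at larger amounts of compound and lower numbers for an effect already at smaller amounts. Compound 2 `Cn1c(CN2CCC(c3ccc(Cl)cc3)CC2)nc2ccccc21` carries chloro in place of hydrogen on an aromatic carbon and gives 79.4 nM in this assay, a step of a 2.5-fold lower number from compound 1 to compound 2 (0.40 log units; beyond the scatter). Compound 3 `Cn1c(CN2CCN(c3ccc(C(F)(F)F)cn3)CC2)nc2ccccc21` has a different core from compound 1; that difference is not broken down here. In this assay compound 3 gives 501 nM, the highest of the three numbers. Compound 4 `Cn1c(CN2CCN(c3ncc(C(F)(F)F)cc3Cl)CC2)nc2ccccc21` is not yet measured and differs from compound 3 by chloro in place of hydrogen on an aromatic carbon. This is the same kind of change as from compound 1 to compound 2, but at a different place: on a ring with one nitrogen, ortho to a large group, two atoms from the ring nitrogen and meta to a trifluoromethyl group, rather than para to a large group on a ring of carbon only. For compound 4 a step of a 2.0-fold lower number from compound 3 to compound 4 (0.30 log units; within the scatter) is expected in this assay, resting on a 2.5-fold lower number from compound 1 to compound 2 (0.40 log units; beyond the scatter) and widened for the changed place. Compound 4 is estimated at 250 nM in this assay, between 80 nM and 800 nM.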

Compound 4, half-maximal effective concentration: 79.4 nM
Estimate against measurement, compound 4: 3.1-fold (0.50 log units) above; the measured number lies below the stated range.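

Chloro in place of hydrogen on an aromatic carbon gives a lower number on both cores in this assay, with a 6.3-fold lower number from compound 3 to compound 4 (0.80 log units; beyond the scatter) on the core of compound 3, and the two steps cannot be told apart in size: the same change on two cores in this assay, a 2.5-fold lower number (0.40 log units; beyond the scatter) from compound 1 to compound 2 and a 6.3-fold lower number (0.80 log units; beyond the scatter) from compound 3 to compound 4, 2.5-fold (0.40 log units) apart, within the scatter of two such steps. The change therefore carries over from the core of compound 1 to the core of compound 3 in these two pairs. Two pairs do not make a general rule, and the chloro stands at a different place in each, so the effect of the core cannot be separated from that of the place.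

Going by these compounds, whether fluoro, methyl or a nitrile in the position of the chloro on compound 4 would give a similar step remains open. Also open, on these data alone, is whether chloro ortho to a large group on the core of compound 1 would match the step seen on compound 4.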